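Swapping Naphthyl for Acetamidophenyl on an Inactive Scaffold

A few compounds are considered here, and "the series" means these few. Any claim that something is new, unique, unknown or untested is made for them only; others in the source may bear on it.

Compound 1, `CCOC(=O)CCCCCOc1cccc(CN(C(=O)c2ccc(-c3cccc(N(C)C)c3)cc2)C(C)C)c1`: in an ADME assay on Raji cells (Homo sapiens) for cytotoxicity, read by CellTiter-Glo and resazurin assay, with a stated time of 72 h (a lower number here means that less compound is needed, a higher number that more compound is needed for the effect), compound 1 gives > 26000 nM.
Compound 2, `CCOC(=O)CCCCCOc1cccc(CN(C(=O)c2ccc(-c3cccc4ccccc34)cc2)C(C)C)c1`: in this assay compound 2 gives > 26000 nM.

Both values are limits of the assay, not numbers. Compound 2 therefore stands only at a limit, and so does compound 1. Within the data shown here, the single measured change, a step that the two limits leave unreadable from compound 1 to compound 2, cannot be sized because the limit of > 26000 nM in this assay, at which 2 of the 2 values shown sit, holds both values shown.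

Compound 3, `CCOC(=O)CCCCCOc1cccc(CN(C(=O)c2ccc(-c3cccc(NC(C)=O)c3)cc2)C(C)C)c1`, carries 3-acetamidophenyl in place of naphthalen-1-yl on an aromatic carbon. Among the measured compounds shown here, nothing measured separates the two limits, so no direction can be read from them, and the only comparison available, compound 1 against compound 2, is silent. For the measured compounds named here, the most natural expectation is that compound 3 also remains at or near the limit; a readable shift would need the acetamide to change matters on its own, for which no measured step gives support.

Compound 3 is expected to give about 30000 nM, within 8000 nM to 120000 nM, most likely again as a limit. The expected step is a step that the limit leaves unreadable from compound 2 to compound 3, which is estimated to be none beyond the scatter.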

Compound 3, half-maximal effective concentration: > 26000 nM
Compound 3: no number, only a limit; the forecaster's own chance of this, stated with the estimate: 75%; the middle value is on the limit's open side.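

No step can be read between compound 1, compound 2 and compound 3, because each value is a limit of the assay and not a number: the limit of > 26000 nM in this assay, at which 3 of the 3 values shown sit.

The compounds shown leave open whether any group at this aromatic carbon would give a true number in this assay.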